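Dropping a Trifluoromethyl: What Compound 4 Should Show

The compounds below may be only part of what the source reports. "The series", "measured", "known", "first", "only" and "open" are said of these compounds alone.

Compound 3 `N=C(N)c1ccc(-c2ccc(-c3ccc(C(=N)N)cc3)c(C(F)(F)F)c2)cc1` carries a trifluoromethyl group, while compound 1 `N=C(N)c1ccc(-c2ccc(-c3ccc(C(=N)N)cc3)cc2)cc1` lacks it. In a functional assay on L6 cells (Rattus norvegicus) for cytotoxicity (on this read-out lower numbers stand for stronger inhibition and higher numbers for weaker inhibition), compound 3 gives 9400 nM, and compound 1 gives 22100 nM. The change hydrogen in place of trifluoromethyl on an aromatic carbon thus produced a 2.4-fold higher number from compound 3 to compound 1 (0.37 log units; beyond the scatter). Compound 2 `CONC(=N)c1ccc(-c2ccc(-c3ccc(C(=N)NOC)cc3)c(C(F)(F)F)c2)cc1` belongs to a second core; the difference between the two cores is not broken down here. In this assay compound 2 gives 42200 nM. Compound 4 `CONC(=N)c1ccc(-c2ccc(-c3ccc(C(=N)NOC)cc3)cc2)cc1`, not yet measured, differs from compound 2 by hydrogen in place of trifluoromethyl on an aromatic carbon. This is the same kind of change, though here the site is ortho to a large group and meta to a large group rather than ortho to a group of 9 heavy atoms and meta to a group of 9 heavy atoms. A step of about a 1.9-fold higher number from compound 2 to compound 4 (0.28 log units; within the scatter) is expected because the same change gave a 2.4-fold higher number from compound 3 to compound 1 (0.37 log units; beyond the scatter). Compound 4 is therefore estimated at 80000 nM, likely between 30000 nM and 200000 nM.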

Compound 4, half-maximal inhibitory concentration: 118000 nM
Estimate against measurement, compound 4: 1.5-fold (0.17 log units) below, within the range that was stated.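

Removing the trifluoromethyl also raised the number on the core of compound 2, with a 2.8-fold higher number from compound 2 to compound 4 (0.45 log units; beyond the scatter) in this assay. Set side by side, the two steps agree: the same change on two cores in this assay, a 2.4-fold higher number (0.37 log units; beyond the scatter) from compound 3 to compound 1 and a 2.8-fold higher number (0.45 log units; beyond the scatter) from compound 2 to compound 4, 1.2-fold (0.08 log units) apart, within the scatter of two such steps. In this assay the change therefore carried over between these two cores, but two pairs cannot show that it would do so on any other core or in any other assay, and they do not explain why the number moves.

The compounds shown leave open what a fluorine atom, a methyl group or an amine on that same aromatic carbon would do. They also leave open whether such a replacement would give a step of similar size on both cores.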